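The source may hold more compounds than are shown below. What is called first, only, known or untested is meant among the compounds shown, and "the series" means these compounds.

Of the compounds shown here, two have been measured in a functional assay on the whole organism (Tail, strain ICR) with Mus musculus as the target, in the tail flick test, with a stated time of 30 min, at a dose of 25 umol/kg by the oral route; a higher number here means a stronger effect of the compound at the dose given, a lower number a weaker effect. Compound 1 `CC(C)[C@H](NC(=O)CN(c1nc(Cl)nc2[nH]cnc12)C1CC1)C(=O)OCc1ccccc1` gives 33.4% and compound 2 `NCCCC[C@H](NC(=O)CN(c1nc(Cl)nc2[nH]cnc12)C1CC1)C(=O)OCc1ccccc1` gives 26.1%. On the numbers shown, compound 2 sits at the bottom of the two, but its only neighbour, compound 1, is separated from it by no more than the scatter of the method. Compound 3 `CC[C@H](C)[C@H](NC(=O)CN(c1nc(Cl)nc2[nH]cnc12)C1CC1)C(=O)OCc1ccccc1` is the next member. Against compound 2 it differs as follows: sec-butyl in place of 4-aminobutyl on a saturated chain carbon bound to an amide-type nitrogen and a carbonyl carbon. Within the data shown here, the single measured step that bears on this is a number 7.3 percentage points lower from compound 1 to compound 2 (within the scatter), which exchanged isopropyl for 4-aminobutyl at the same place and stayed within the scatter. Compound 3 carries sec-butyl, a group that, like isopropyl, brings no hydrogen-bond donor and no hydrogen-bond acceptor, so a number near that of compound 1 is expected, with no step beyond the scatter in either direction. Compound 3 is therefore estimated at 32%, range 20% to 45%, meaning an expected step of a number 5.9 percentage points higher from compound 2 to compound 3 (within the scatter).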

Compound 3, a percentage reported as activity, at one dose (the size of the read-out at that dose, not a potency): 41.4%
The estimate for compound 3 lay 9.4 percentage points below the measured number, within the range that was stated.
By their numbers in this assay, from the lowest: compounds 2, 1 and 3 (each within the scatter of the next, the first and the last beyond it).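

At this position, this assay now shows a step beyond the scatter: a number 15.3 percentage points higher from compound 2 to compound 3 (beyond the scatter) with sec-butyl in place of 4-aminobutyl on a saturated chain carbon bound to an amide-type nitrogen and a carbonyl carbon. By contrast, methyl in place of hydrogen on a saturated chain carbon, three bonds along the chain from an amide-type nitrogen and a carbonyl carbon, gives a number 8 percentage points higher from compound 1 to compound 3 (within the scatter) and so does not separate sec-butyl from isopropyl. Nothing shown explains why sec-butyl and 4-aminobutyl separate here.

As far as these compounds go, whether the separation follows the amine of 4-aminobutyl or its longer chain stays open, and an unbranched n-butyl group at this place would bear on that. From the compounds shown here alone, how a carboxylic acid at the same place would read out also stays open.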